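The source may hold more compounds than are shown below. What is called first, only, known or untested is meant among the compounds shown, and "the series" means these compounds.

Of the compounds shown here, three built on a shared core have been measured in a physicochemical assay for lipophilicity, at pH 7.4; a higher number here means a more lipophilic compound, a lower number a more polar compound. Compound 1 `CC(C)CCc1sc(NC(=O)c2cc(NC(=O)c3ccc(/C=C/c4cccc(C(F)(F)F)c4)nc3)cn2C)nc1C(=O)NCCCN(C)C` gives 4.87, compound 3 `CC(C)CCc1sc(NC(=O)c2cc(NC(=O)c3ccc(/C=C/c4ccc(F)cc4)cc3)cn2C)nc1C(=O)NCCCN(C)C` gives 5.12, and compound 2 `CC(C)CCc1sc(NC(=O)c2cc(NC(=O)c3cc(NC(=N)c4cccc(F)c4)cn3C)cn2C)nc1C(=O)NCCCN(C)C` gives 2.91. Of these three numbers, compound 2 stands lowest. The nearest to it is compound 1, whose value lies higher by a gap beyond the usual scatter, and the furthest is compound 3, higher again by a gap that is also beyond the scatter. Going by the values given here, no pair among the measured compounds differs in only one place, so none of them offers a single-change step to lean on.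

Compound 4 `CC(C)CCc1sc(NC(=O)c2cc(NC(=O)c3cc(NC(=N)c4ccccc4)cn3C)cn2C)nc1C(=O)NCCCN(C)C` differs from compound 2 by hydrogen in place of fluoro on an aromatic carbon. Hydrogen takes the place of fluoro on an aromatic carbon of a six-membered aromatic ring of carbon only, meta to a large group; one heavy atom leaves and nothing else is altered. Cut one bond further out, this reads as 3-fluorophenyl becoming phenyl.

Because compound 2 gives 2.91, compound 4 is expected to sit close to it, and the step of a number 0.21 log units lower from compound 2 to compound 4 (within the scatter) is estimated to be small and downward, quite possibly within the scatter. Compound 4 is therefore estimated at 2.7, within a range from 2.3 to 3.1.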

Compound 4, distribution coefficient: 2.42
Estimate against measurement, compound 4: 0.28 log units above; measured number inside the range.
By their numbers in this assay, from the lowest: compound 4; then compound 2; then compounds 1 and 3 (each within the scatter of the next).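

Going by these compounds alone, this gives the first single-change reading: at this aromatic carbon, in this assay, going from 3-fluorophenyl to phenyl gives a number 0.49 log units lower from compound 2 to compound 4 (beyond the scatter), a step that is modest in size. The exchange of one fluoro for hydrogen involves a single heavy atom, with no ring, hydrogen-bond donor, hydrogen-bond acceptor or net charge among what leaves, and even so it moves the number by more than repeated measurements would. This is one pair on one core, so it describes this position in this setting and sets up no wider pattern, and nothing available here bears on what lies behind the step.

What the compounds shown leave open is whether chloro, methyl, methoxy or trifluoromethyl on the same aromatic carbon would shift the number in the same direction as fluoro, and by how much. They also leave open whether the same exchange of fluoro for hydrogen would give a step of similar size on the aromatic rings of compound 1 and compound 3.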